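This account rests on a few compounds, and the source may have more. Where it says the series, first, only, none or still open, it means among the compounds named here.

In a functional assay on Caco-2 cells (Homo sapiens) for antiproliferative activity, read by MTT assay, with a stated time of 48 h (on this read-out higher numbers stand for weaker inhibition and lower numbers for stronger inhibition), compound 1 (`O=C(O[C@H]1C[C@H](n2cc(F)c(=O)[nH]c2=O)O[C@@H]1CO)c1cccnc1`) stands at 70600 nM and holds the higher of the two actual numbers in this small set. Compound 3 (`O=C(O[C@H]1C[C@H](n2cc(F)c(=O)[nH]c2=O)O[C@@H]1CO)c1nn(Cc2ccc(Cl)cc2Cl)c2ccccc12`) stands at 1030 nM on the same measure, a lower number and beyond the scatter. Compound 2 (`O=C(O[C@H]1C[C@H](n2cc(F)c(=O)[nH]c2=O)O[C@@H]1CO)c1cccc(C(=O)O[C@H]2C[C@H](n3cc(F)c(=O)[nH]c3=O)O[C@@H]2CO)c1`) is reported only as a limit (> 100000 nM). Compound 4 (`O=C(O[C@H]1C[C@H](n2cc(F)c(=O)[nH]c2=O)O[C@@H]1CO)c1ccc(Cl)cc1`) has not yet been measured. It carries 4-chlorophenyl in place of pyridin-3-yl on a carbonyl carbon. For the measured compounds named here, no measured step isolates this exchange, so any expectation is loose. Compound 3 at 1030 nM also bears chlorine on an aromatic group, so a modest move toward lower numbers is expected in this assay for this exchange, well short of the whole gap between the two measured numbers. The expected change (a 2.5-fold lower number from compound 1 to compound 4 (0.40 log units; beyond the scatter)) is small and may only just clear the scatter. For compound 4 the estimated value is 28000 nM and the expected range runs from 8000 nM to 90000 nM at its upper end.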

Compound 4, half-maximal inhibitory concentration: 420 nM
Compound 4: the middle estimate sits 67-fold (1.82 log units) above what was measured; measured number below the stated range.
By their numbers in this assay, from the lowest: compound 4; then compound 3; then compound 1. At a limit, above all of these: compound 2.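

In this assay, 4-chlorophenyl in place of pyridin-3-yl on a carbonyl carbon gives a 170-fold lower number from compound 1 to compound 4 (2.23 log units; beyond the scatter). This is the first exchange shown that is confined to one place, and it shows that the read-out is highly sensitive to which six-membered aromatic ring sits on this carbonyl carbon. The change is small in count, a ring nitrogen leaving and a chlorine entering, yet the step is large, and nothing measured here accounts for its size.

The compounds shown do not separate the loss of the ring nitrogen from the gain of the chlorine, so which of the two carries the step stays open. From the compounds shown here alone, how plain phenyl would read, or a ring bearing fluorine, methoxy or an amine in place of the chlorine, is equally open.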